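The source may report more compounds than this note shows. Statements on the series, on what has been measured and on what is new or still open speak of the compounds shown alone.

Compound 1 `CCOC(=O)/C=C/c1ccncc1-c1ccc2c(cnn2C)c1`: > 10000 nM, a limit
Compound 2 `O=C(O)/C=C/c1ccncc1-c1ccc2ccccc2c1`: > 10000 nM, a limit
Compound 3 `Cn1ncc2cc(-c3cnccc3/C=C/C(=O)O)ccc21`: > 10000 nM, a limit

These readings come from a functional assay on MDA-MB-231 cells (Homo sapiens) for inhibition, read by sulforhodamine B assay, with a stated time of 72 h; a higher number here means a weaker inhibitor of growth, a lower number a stronger inhibitor of growth. A value with a greater-than sign is a limit of the assay and not a number. Compound 2 stands at > 10000 nM, which is such a limit.

The unmeasured compound 4 `NC(=O)/C=C/c1ccncc1-c1ccc2ccccc2c1` differs from compound 2 in one place: amino in place of hydroxy on a carbonyl carbon. This is amino in place of hydroxy on a carbonyl carbon, so 2-carboxyethenyl becomes 2-carbamoylethenyl.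

For the measured compounds named here, only one measured step also changes a group on a carbonyl, and it sits on the core of compound 1: a step that the two limits leave unreadable from compound 1 to compound 3. It gives no size to carry over. The whole set offers only (the limit of > 10000 nM in this assay, at which 3 of the 3 values shown sit).

With no readable step to go on, I expect no change beyond the usual scatter in this assay and favour no direction. Another limit would be the likeliest result.

The expected change is a step that the limit leaves unreadable from compound 2 to compound 4.

Compound 4 is estimated at 12000 nM, with an expected range of 4000 nM to 36000 nM.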

Compound 4, concentration for 50% growth inhibition: > 10000 nM
Compound 4: a limit, no number; the forecaster's own chance of this, stated with the estimate: 70%; the middle value lies beyond the limit too.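

For the compounds shown here, compound 2 and compound 4 each give only a limit of the assay and not a number, so no step between them can be read. The compounds shown leave open how strongly any of them inhibits growth, and whether amino in place of hydroxy on a carbonyl carbon changes that: the limit of > 10000 nM in this assay, at which 4 of the 4 values shown sit.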